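Removing one phosphate from a benzylsulfanyl cytidine diphosphate

The source may report more compounds than this note shows. Statements on the series, on what has been measured and on what is new or still open speak of the compounds shown alone.

Compound 1 `Nc1nc(=O)ccn1[C@@H]1O[C@H](COP(=O)(O)OP(=O)(O)O)[C@@H](O)[C@H]1O` gives >= 100000 nM in an in vitro functional assay on 1321-N1 cells for agonist activity at P2Y purinoceptor 4 (Homo sapiens), read by scintillation proximity assay and inositol phosphate accumulation (on this read-out higher numbers stand for an effect only at larger amounts of compound and lower numbers for an effect already at smaller amounts), which is a limit of the assay and not a number. Compound 2 `Nc1nc(=O)ccn1[C@@H]1O[C@H](COP(=O)(O)O)[C@@H](O)[C@H]1O` gives 4980 nM. Compound 3 `O=c1ccn([C@@H]2O[C@H](COP(=O)(O)OP(=O)(O)O)[C@@H](O)[C@H]2O)c(SCc2ccccc2)n1` gives 5980 nM.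

From compound 1 to compound 2 the change is a hydrogen atom in place of a group of 4 heavy atoms (3 oxygen, 1 phosphorus; no ring), on an oxygen and the step is an at least 20-fold lower number from compound 1 to compound 2 (1.30 log units; beyond the scatter); its size is only a bound because of the limit of >= 100000 nM in this assay, at which 1 of the 3 values shown sits. The cores of compounds 1 and 3 differ by benzylsulfanyl in place of amino on an aromatic carbon, with a step of an at least 16-fold lower number from compound 1 to compound 3 (1.22 log units; beyond the scatter). Compound 2 and compound 3 sit within the scatter of each other.

Compound 4 `O=c1ccn([C@@H]2O[C@H](COP(=O)(O)O)[C@@H](O)[C@H]2O)c(SCc2ccccc2)n1` is not yet measured. It differs from compound 3 by a hydrogen atom in place of a group of 4 heavy atoms (3 oxygen, 1 phosphorus; no ring), on an oxygen, the same change as from compound 1 to compound 2, at the same place. Because an at least 20-fold lower number from compound 1 to compound 2 (1.30 log units; beyond the scatter) went strongly downward, a step of a 4.0-fold lower number from compound 3 to compound 4 (0.60 log units; beyond the scatter) is expected, though compound 3 already starts lower than compound 1 did. Compound 4 is estimated at 1500 nM, between 300 nM and 8000 nM.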

Compound 4, half-maximal effective concentration: > 100000 nM
Compound 4 ended at the assay's limit; the forecaster's own chance of this, stated with the estimate: 5%; at least 66-fold (1.82 log units) between middle value and limit.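

Compound 4 gives > 100000 nM in this assay, a limit of the assay and not a number, so the steps to it show only a minimum size. Removing one phosphate gives an at least 16-fold higher number from compound 3 to compound 4 (1.22 log units; beyond the scatter), the opposite direction to the same change on the other core: the same change on two cores in this assay, an at least 20-fold lower number (1.30 log units; beyond the scatter) from compound 1 to compound 2 and an at least 16-fold higher number (1.22 log units; beyond the scatter) from compound 3 to compound 4, at least 330-fold (2.52 log units) apart, beyond the scatter of two such steps Benzylsulfanyl in place of amino does not carry over from one core to the other either, giving an at least 20-fold higher number from compound 2 to compound 4 (1.30 log units; beyond the scatter), and these four compounds show that the two changes depend on each other but not why: the same change on two cores in this assay, an at least 16-fold lower number (1.22 log units; beyond the scatter) from compound 1 to compound 3 and an at least 20-fold higher number (1.30 log units; beyond the scatter) from compound 2 to compound 4, at least 330-fold (2.52 log units) apart, beyond the scatter of two such steps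

Going by these compounds, whether the same reversal appears with a smaller group such as methylsulfanyl on that aromatic carbon stays open. So does how a triphosphate chain would behave on either core.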